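Fluoro to trifluoromethyl at a new place

The compounds below may be only part of what the source reports. "The series", "measured", "known", "first", "only" and "open" are said of these compounds alone.

In a functional assay on MCF7 cells (Homo sapiens) for antiproliferative activity, read by MTT assay, with a stated time of 24 h (a higher number here means a weaker inhibitor, a lower number a stronger inhibitor), three related compounds have been measured so far. Compound 1 `Cc1ccc(C)c(S(=O)(=O)n2c(-c3cn(-c4ccccc4)nc3-c3ccc(F)cc3)nc3ccccc32)c1` gives 430 nM, compound 3 `O=S(=O)(c1ccc(C(F)(F)F)cc1)n1c(-c2cn(-c3ccccc3)nc2-c2ccc(F)cc2)nc2ccccc21` gives 1580 nM, and compound 2 `O=S(=O)(c1ccc(F)cc1)n1c(-c2cn(-c3ccccc3)nc2-c2ccc(F)cc2)nc2ccccc21` gives 3670 nM, the highest number of the three and so the weakest inhibitor among them.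

Compound 4 `O=S(=O)(c1ccc(F)cc1)n1c(-c2cn(-c3ccccc3)nc2-c2ccc(C(F)(F)F)cc2)nc2ccccc21` has not been measured yet. It differs from compound 2 by a single change: trifluoromethyl in place of fluoro on an aromatic carbon. In words, this is trifluoromethyl in place of fluoro on an aromatic carbon, while the 4-fluorophenyl on the sulfonyl sulfur stays as it is.

The closest guide is the same swap made on the group attached to the sulfonyl sulfur, a modest step of a 2.3-fold lower number from compound 2 to compound 3 (0.37 log units; beyond the scatter). The other two measured steps, an 8.5-fold higher number from compound 1 to compound 2 (0.93 log units; beyond the scatter) and a 3.7-fold higher number from compound 1 to compound 3 (0.57 log units; beyond the scatter), also change that sulfonyl group, so they show only that this assay responds to changes there. Among the measured compounds shown here, no measured compound varies the ring altered in compound 4, so the guide is a loose one.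

A slight lean towards a lower number is expected, staying within the scatter, and the expected step is a 1.7-fold lower number from compound 2 to compound 4 (0.22 log units; within the scatter). For compound 4 the estimate is 2200 nM, with an expected range from 800 nM to 6000 nM.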

Compound 4, half-maximal inhibitory concentration: 3120 nM
The estimate for compound 4 lay 1.4-fold (0.15 log units) below the measured number; measured number inside the range.
By their numbers in this assay, from the lowest: compound 1; then compounds 3, 4 and 2 (each within the scatter of the next, the first and the last beyond it).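

In this assay, moving the swap of fluoro for trifluoromethyl to the 4-fluorophenyl held by the shared core, away from the one on the sulfonyl sulfur, gives a 1.2-fold lower number from compound 2 to compound 4 (0.07 log units; within the scatter) and so leaves the number unchanged within the usual variation between repeats. The same swap on the group at the sulfonyl sulfur gave a 2.3-fold lower number from compound 2 to compound 3 (0.37 log units; beyond the scatter) and therefore did move the number, so in these two steps the result depends on where the change is made and cannot simply be carried from one place to the other. Nothing measured among these data accounts for this contrast between the two places.

The compounds shown carry only fluoro and trifluoromethyl at this place, so it remains open whether a quite different group, such as an amine, a carboxylic acid or a longer chain, would shift the number there. From the compounds shown here alone, it is also open whether the swap would behave the same way with the 2,5-dimethylphenyl of compound 1 on the sulfonyl sulfur in place of the 4-fluorophenyl.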